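Series Notes: Substitution on the Aromatic Nitrogen and Potency

This account rests on a few compounds, and the source may have more. Where it says the series, first, only, none or still open, it means among the compounds named here.

Compound 3 `CCCC[C@H](NC(=O)OC(C(C)C)C(C)C)C(=O)C(=O)Nc1ccnn1C1CCC1` gives 1100 nM in an assay on isolated protein for inhibition of cathepsin K (Rattus norvegicus) (a higher number here means a weaker inhibitor, a lower number a stronger inhibitor), the second highest of the three numbers measured. Compound 2 `CCCC[C@H](NC(=O)OC(C(C)C)C(C)C)C(=O)C(=O)Nc1ccnn1CCC(C)(C)C` gives 1600 nM, and a 1.5-fold lower number from compound 2 to compound 3 (0.16 log units; within the scatter). Compound 1 `CCCC[C@H](NC(=O)OC(C(C)C)C(C)C)C(=O)C(=O)Nc1cc(-c2ccccc2)[nH]n1` gives 12 nM, far lower than compound 3 and beyond the scatter. Compound 4 `CCCC[C@H](NC(=O)OC(C(C)C)C(C)C)C(=O)C(=O)Nc1cc[nH]n1` differs from compound 3 by 1H-pyrazol-3-yl in place of 1-cyclobutyl-1H-pyrazol-5-yl on an amide-type nitrogen, so the entering group carries 1 hydrogen-bond donor. Going by the values given here, no measured step covers this change directly; the one step available, a 1.5-fold lower number from compound 2 to compound 3 (0.16 log units; within the scatter), exchanges one group for another on an aromatic nitrogen and stays within the scatter. Among the compounds with values here, compound 1 is the only measured compound with an unsubstituted aromatic nitrogen and sits far lower, so a lower number is expected for compound 4, with a 7.3-fold lower number from compound 3 to compound 4 (0.87 log units; beyond the scatter) as the expected step. Compound 4 is estimated at 150 nM, range 30 nM to 800 nM.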

Compound 4, half-maximal inhibitory concentration: 13 nM
For compound 4 the middle estimate is 12-fold (1.06 log units) above the measured one, outside the stated range (below it).
By their numbers in this assay, from the lowest: compounds 1 and 4 (each within the scatter of the next); then compounds 3 and 2 (each within the scatter of the next).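

In this assay the exchange on the amide-type nitrogen gives an 85-fold lower number from compound 3 to compound 4 (1.93 log units; beyond the scatter) and so, unlike the step between the two substituted compounds, lies far beyond the scatter. With hydrogen in place of phenyl on the aromatic carbon, the series shows a 1.1-fold higher number from compound 1 to compound 4 (0.03 log units; within the scatter) and thus no readable effect of that phenyl group. No measured evidence bears on the cause of the large step.

The compounds shown do not separate removal of the cyclobutyl group from the change between 1H-pyrazol-5-yl and 1H-pyrazol-3-yl attachment. From the compounds shown here alone, whether a methyl group on the aromatic nitrogen would keep the number of compound 4 also remains open.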